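Chain Extension on the Shared Core of Compound 1

A few compounds are considered here, and "the series" means these few. Any claim that something is new, unique, unknown or untested is made for them only; others in the source may bear on it.

Among the measured compounds shown here, compound 1 `CCCC(=O)c1c(OC)c(Cl)c(OC)c(Cl)c1OC` gives 144000 nM in an ADME assay on the whole organism (strain S2) for cytotoxicity, with Drosophila as the target, read by WST assay (a lower number here means that less compound is tolerated, a higher number that more compound is tolerated), the highest of the three numbers measured so far. Compound 2 `CCCCCC(=O)c1c(O)c(Cl)c(O)c(Cl)c1O` gives 102000 nM and compound 3 `CCCCCCCCC(=O)c1c(O)c(Cl)c(O)c(Cl)c1O` gives 82800 nM; both gaps to compound 1 lie within the scatter. The unmeasured compound 4 `CCCCCCC(=O)c1c(OC)c(Cl)c(OC)c(Cl)c1OC` differs from compound 1 by propyl in place of hydrogen on a saturated chain carbon, three bonds along the chain from a carbonyl carbon. For the measured compounds named here, the only measured step that bears on this change is a 1.2-fold lower number from compound 2 to compound 3 (0.09 log units; within the scatter), which adds the same group five bonds along the chain from a carbonyl carbon on the core of compound 2. On that basis compound 4 is expected to sit near compound 1, with an estimated step of a 1.3-fold lower number from compound 1 to compound 4 (0.12 log units; within the scatter) that stays within the scatter. The estimated value for compound 4 is 110000 nM, in a range from 60000 nM to 220000 nM.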

Compound 4, half-maximal cytotoxic concentration: 140000 nM
For compound 4 the middle estimate is 1.3-fold (0.10 log units) below the measured one, and the stated range covers the measured number.
By their numbers in this assay, from the lowest: compounds 3, 2, 4 and 1 (each within the scatter of the next).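

In this assay, propyl in place of hydrogen on a saturated chain carbon, three bonds along the chain from a carbonyl carbon, gives a 1.0-fold lower number from compound 1 to compound 4 (0.01 log units; within the scatter). Among the compounds shown here, until now this change had been seen only on the core of compound 2, five bonds along the chain from a carbonyl carbon. It now stands on a second core, and the two steps agree: the same change on two cores in this assay, a 1.2-fold lower number (0.09 log units; within the scatter) from compound 2 to compound 3 and a 1.0-fold lower number (0.01 log units; within the scatter) from compound 1 to compound 4, 1.2-fold (0.08 log units) apart, within the scatter of two such steps

From the compounds shown here alone, whether a longer chain, or an amine or a carboxylic acid at the chain end, would stay within the scatter remains open. Going by these compounds, what hydroxy in place of methoxy does on its own also remains open.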